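The compounds below may be only part of what the source reports. "The series", "measured", "known", "first", "only" and "open" are said of these compounds alone.

Measured so far:
- Compound 1, `Cc1cc(NS(=O)(=O)c2ccc(N/C(S)=N\c3ccnc4cc(C(F)(F)F)ccc34)cc2)on1`, gives 80300 nM.
- Compound 2, `O=S(=O)(Nc1ncccn1)c1ccc(N/C(S)=N\c2ccnc3cc(C(F)(F)F)ccc23)cc1`, gives 45200 nM.
- Compound 3, `Cc1ccnc(NS(=O)(=O)c2ccc(N/C(S)=N\c3ccnc4cc(C(F)(F)F)ccc34)cc2)n1`, gives 29800 nM.

These three numbers come from a functional assay on MDA-MB-231 cells (Homo sapiens) for antiproliferative activity, read by sulforhodamine B assay, with a stated time of 48 h; a higher number here means a weaker inhibitor, a lower number a stronger inhibitor. Compound 3 carries the lowest number of the three, but its separation from compound 2 is only a 1.5-fold lower number from compound 2 to compound 3 (0.18 log units; within the scatter), so the two cannot be ordered; only against compound 1 does compound 3 stand apart, by a 2.7-fold lower number from compound 1 to compound 3 (0.43 log units; beyond the scatter).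

Compound 4, `COc1cc(NS(=O)(=O)c2ccc(N/C(S)=N\c3ccnc4cc(C(F)(F)F)ccc34)cc2)nc(OC)n1`, differs from compound 3 in one place: 2,6-dimethoxypyrimidin-4-yl in place of 4-methylpyrimidin-2-yl on a sulfonamide nitrogen. Within the data shown here, the steps that bear on this are the two earlier swaps of the group on the sulfonamide nitrogen, a 1.8-fold lower number from compound 1 to compound 2 (0.25 log units; within the scatter) and a 2.7-fold lower number from compound 1 to compound 3 (0.43 log units; beyond the scatter), which show that exchanging one heteroaryl for another at this position has moved the number by little, at most a modest amount. Among the measured compounds shown here, no earlier step introduces methoxy groups or the same attachment pattern, so the direction remains open. The expected step in this assay from compound 3 is therefore a 1.1-fold higher number from compound 3 to compound 4 (0.03 log units; within the scatter), with none beyond the scatter foreseen. Compound 4 is estimated at 32000 nM, within a range from 10000 nM to 95000 nM.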

Compound 4, half-maximal inhibitory concentration: 52100 nM
The estimate for compound 4 lay 1.6-fold (0.21 log units) below the measured number; the measured number falls inside the stated range.
By their numbers in this assay, from the lowest: compounds 3, 2, 4 and 1 (each within the scatter of the next, the first and the last beyond it).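

In this assay, the 2,6-dimethoxypyrimidin-4-yl group on the sulfonamide nitrogen, which has more heavy atoms and more hydrogen-bond acceptors than 4-methylpyrimidin-2-yl, stays within the scatter of all three earlier groups, with a 1.7-fold higher number from compound 3 to compound 4 (0.24 log units; within the scatter) and a 1.2-fold higher number from compound 2 to compound 4 (0.06 log units; within the scatter) and a 1.5-fold lower number from compound 1 to compound 4 (0.19 log units; within the scatter). Among these compounds, compound 4 therefore cannot be ordered against any other compound, and it shows that adding two methoxy groups and changing the point of attachment of the pyrimidine opens no separation at this position, where compound 3 and compound 1 remain the only pair beyond the scatter. Nothing available alongside these numbers accounts for this result.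

The compounds shown leave open whether a group on the sulfonamide nitrogen that is not a heteroaryl, such as a plain phenyl ring or a short chain ending in an amine or a carboxylic acid, would move the number beyond the scatter. They also leave open what a change elsewhere on the shared core would do, for example chlorine or methoxy in place of trifluoromethyl.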